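This account rests on a few compounds, and the source may have more. Where it says the series, first, only, none or still open, it means among the compounds named here.

For the measured compounds named here, in a functional assay on MX1 cells (Homo sapiens) for antiproliferative activity, with a stated time of 72 h (a lower number here means that less compound is needed, a higher number that more compound is needed for the effect), the three compounds measured so far spread widely. Compound 1 `Cn1cc(-c2ccccc2Oc2ccccc2)cc(N)c1=O` gives only a limit of the assay, > 5000 nM, and not a number. Compound 2 `Cn1cc(-c2cc(C(N)=O)ccc2Oc2ccccc2)c2cc[nH]c2c1=O` gives a true number, 120 nM. Compound 3 `CCS(=O)(=O)Nc1ccc(Oc2ccc(C(F)(F)F)cc2)c(-c2cn(C)c(=O)c3[nH]ccc23)c1` gives 30 nM, the lower of the two true numbers, and its gap to compound 2 lies beyond the usual scatter of repeated measurements.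

The next step starts from compound 3. Compound 4 `CCS(=O)(=O)Nc1ccc(OC2CCN(C)CC2)c(-c2cn(C)c(=O)c3[nH]ccc23)c1` keeps the rest of that structure but has 1-methylpiperidin-4-yl in place of 4-(trifluoromethyl)phenyl on an oxygen on an aromatic ring. A ring of carbon only, with no hydrogen-bond acceptor, thus gives way to a smaller non-aromatic ring that holds a nitrogen and counts one acceptor.

Going by the values given here, no measured pair shows this kind of swap, so the expectation is a cautious one. Each measured compound carries an aromatic ring on that oxygen, and compound 3 already sits low at 30 nM, so a higher number seems more likely than a lower one. The estimated step, a 6.7-fold higher number from compound 3 to compound 4 (0.82 log units; beyond the scatter), is expected to be moderate, and beyond the scatter. For compound 4 the expected value is 200 nM, within an estimated range of 50 nM to 1000 nM.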

Compound 4, half-maximal effective concentration: 210 nM
Compound 4: middle estimate off by 1.1-fold (0.02 log units), on the low side, and the stated range covers the measured number.
By their numbers in this assay, from the lowest: compound 3; then compounds 2 and 4 (each within the scatter of the next). At a limit, above all of these: compound 1.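

In this assay the change from 4-(trifluoromethyl)phenyl to 1-methylpiperidin-4-yl gives a 7.0-fold higher number from compound 3 to compound 4 (0.85 log units; beyond the scatter) and so shows that the group on this oxygen does affect the result. For the compounds shown here, every earlier compound carried an aromatic ring at this place, so this is the first view of a non-aromatic ring there. The step is modest, and compound 4 gives 210 nM as a true number and not a limit of the assay, so a non-aromatic ring holding a nitrogen can stand on this oxygen and still leave a measurable effect.

Still open is which part of the swap accounts for the step, since the aromatic ring, the trifluoromethyl group and the ring nitrogen all change at once, and a plain phenyl, a cyclohexyl or a piperidin-4-yl with no methyl on its nitrogen would each help to pull these apart, as would an open chain such as 2-(dimethylamino)ethyl. Nothing measured here gives a reason for the size of this step.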